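A few compounds are considered here, and "the series" means these few. Any claim that something is new, unique, unknown or untested is made for them only; others in the source may bear on it.

Of the compounds shown here, three sharing one core have been measured in a functional assay, with a stated time of 60 min, tested at 0.1 mM; a lower number here means a weaker effect, a higher number a stronger effect of the compound at the concentration tested. Compound 1 `Cn1c(=O)c(C(=O)NCCN)c(O)c2ccccc21` gives 11.5%, compound 2 `Cn1c(=O)c(C(=O)NCCCCCCN)c(O)c2ccccc21` gives 8.3%, and compound 3 `NCCCCCCNC(=O)c1c(O)c2ccccc2n(-c2ccccc2)c1=O` gives 17.5%. On the numbers alone compound 2 stands lowest of the three, but its distance to both neighbours is small: the step of a number 3.2 percentage points lower from compound 1 to compound 2 (within the scatter) and the step of a number 9.2 percentage points higher from compound 2 to compound 3 (within the scatter) both lie within the scatter, so no ordering among the three can be claimed.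

Compound 4 `Cn1c(=O)c(C(=O)Nc2ccc(N)cc2)c(O)c2ccccc21` is now to be measured in this assay. It differs from compound 2 in one place: 4-aminophenyl in place of 6-aminohexyl on an amide-type nitrogen. Neither measured step bears directly on this change. Among the compounds with values here, the step of a number 3.2 percentage points lower from compound 1 to compound 2 (within the scatter) alters the length of the chain carrying the amino group, and the step of a number 9.2 percentage points higher from compound 2 to compound 3 (within the scatter) alters the group on the aromatic nitrogen; no measured pair exchanges a saturated chain for an aromatic ring on the amide-type nitrogen. Both measured steps were small, and all three numbers sit in the same low band. Compound 4 is therefore expected to give a number close to that of compound 2, with the step of a number 3.7 percentage points higher from compound 2 to compound 4 (within the scatter) expected to fall within the scatter. The estimate for compound 4 is 12%, in a range from 2% to 28%.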

Compound 4, a percentage reported as activity, at one concentration (the size of the read-out at that concentration, not a potency): 88.1%
For compound 4 the middle estimate is 76.1 percentage points below the measured one; measured number above the stated range.
By their numbers in this assay, from the lowest: compounds 2, 1 and 3 (each within the scatter of the next); then compound 4.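

In this assay the amide-type nitrogen proves to be a place where the read-out can move a long way: the step of a number 79.8 percentage points higher from compound 2 to compound 4 (beyond the scatter) comes with 4-aminophenyl replacing 6-aminohexyl, two groups equal in heavy atoms, hydrogen-bond donors and hydrogen-bond acceptors, so those counts do not separate them. The step of a number 76.6 percentage points higher from compound 1 to compound 4 (beyond the scatter) with 4-aminophenyl replacing 2-aminoethyl is also large, whereas the exchange between the two saturated chains stayed within the scatter, so here the large change appears only when an aromatic ring replaces a chain. No measurement available here explains this difference.

The compounds shown leave open whether the aromatic ring alone accounts for these steps or whether its amino group is also needed, a question that a plain phenyl or a 4-hydroxyphenyl group on the amide-type nitrogen would address. They also leave open whether a benzyl group, with a single saturated carbon before the ring, would behave like 4-aminophenyl, and whether the same exchange would have a similar effect with phenyl rather than methyl on the aromatic nitrogen.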